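LRRK2 series notes: trifluoromethyl for hydroxymethylpiperidinyl

The source may hold more compounds than are shown below. What is called first, only, known or untested is meant among the compounds shown, and "the series" means these compounds.

Two compounds of the series carry measurements in an assay on Sf9 cells for inhibition of Leucine-rich repeat serine/threonine-protein kinase 2 (Homo sapiens), read by TR-FRET, with stated times of 30 min and 2 h; a lower number here means a stronger inhibitor, a higher number a weaker inhibitor. Compound 1 `O=C(Nc1cccc(Cl)c1)c1cc(C(F)(F)F)ccc1OCc1ccc(F)cc1` gives 12.6 nM in this assay. Compound 2 `O=C(Nc1ccnnc1)c1cc(N2CCC(CO)CC2)ccc1OCc1ccccc1` gives 20 nM in this assay; its number and that of compound 1 lie within the usual scatter of each other, so the two readings cannot be told apart and neither compound can be set above the other on these data.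

Compound 3 `O=C(Nc1ccnnc1)c1cc(C(F)(F)F)ccc1OCc1ccccc1` is the next member to be measured in this assay. It differs from compound 2 in one place: trifluoromethyl in place of 4-(hydroxymethyl)piperidin-1-yl on an aromatic carbon. Among the measured compounds shown here, the group entering is the one already present in compound 1, while the pyridazinylcarbamoyl and benzyloxy groups of compound 2 are kept. No step between measured compounds covers this change, so the size of the step is not shown by the data.

Since compound 1 with the entering group gives 12.6 nM and compound 2 gives 20 nM, the expectation for compound 3 is a reading within the scatter of both, with an estimated step of a 1.3-fold lower number from compound 2 to compound 3 (0.12 log units; within the scatter). In this assay compound 3 is estimated at 15 nM, with a range from 5 nM to 50 nM.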

Compound 3, half-maximal inhibitory concentration: 15.9 nM
The estimate for compound 3 lay 1.1-fold (0.03 log units) below the measured number; the range from low to high includes it.
By their numbers in this assay, from the lowest: compounds 1, 3 and 2 (each within the scatter of the next).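

In this assay the exchange at this position gives a 1.3-fold lower number from compound 2 to compound 3 (0.10 log units; within the scatter), so the two readings cannot be told apart. Among the compounds shown here, this is the first step read at the position para to the benzyloxy group and meta to the (pyridazin-4-yl)carbamoyl group, and it shows that a large exchange of groups there leaves no difference beyond the scatter: 4-(hydroxymethyl)piperidin-1-yl, with 8 heavy atoms, a six-membered non-aromatic ring and 1 hydrogen-bond donor, gives way to trifluoromethyl, with 4 heavy atoms, no ring and 0 hydrogen-bond donors. For this one pair, then, neither the ring nor the hydroxymethyl group is needed to keep the reading within the scatter of compound 2. No measurement here bears on why the two groups read alike.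

Going by these compounds, whether the position tolerates other groups stays open, for instance a carboxylic acid, a primary amine or a longer alkyl chain. On these data alone, it is also open whether the same exchange reads alike when the pyridazinylcarbamoyl and benzyloxy groups are replaced, since this single step rests on one pair.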